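A few compounds are considered here, and "the series" means these few. Any claim that something is new, unique, unknown or untested is made for them only; others in the source may bear on it.

Measured so far:
- compound 1, `CN1CCN(Nc2cccc3c2C[C@@H](CN(C)[C@H]2CCCc4cccnc42)NC3)CC1`: 73.6%
- compound 2, `CN1C[C@@H]2CN(c3cccc4c3C[C@H](CN(C)[C@H]3CCCc5cccnc53)NC4)C[C@@H]2C1`: 100%

In an ADME assay on microsomes from liver (Homo sapiens) for metabolic stability, using NADPH, with a stated time of 10 min (a lower number here means that less of the compound is left, a higher number that more of the compound is left), compound 1 gives 73.6%, while compound 2 gives 100%. For the measured compounds named here, compound 2 stands highest of the two numbers; its only neighbour, compound 1, lies lower by a gap beyond the scatter, so compound 2 is the more stable of the pair in this assay.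

Compound 3, `CN(C)[C@H]1CCN(c2cccc3c2C[C@H](CN(C)[C@H]2CCCc4cccnc42)NC3)C1`, has not been measured in this assay. It differs from compound 2 in one place: a group of 8 heavy atoms (6 carbon, 2 nitrogen; one five-membered non-aromatic ring with 1 hetero atom) in place of a group of 9 heavy atoms (7 carbon, 2 nitrogen; 2 five-membered non-aromatic rings with 1 hetero atom each), on an aromatic carbon.

Going by the values given here, no measured pair shows this change, so there is no direct template for the step. With compound 2 already at the top of the read-out, the step can only hold or fall. The expected step of a number 15 percentage points lower from compound 2 to compound 3 (beyond the scatter) is a modest decrease, close to the edge of the usual scatter, given that compound 1 with a different group at the same place sits at 73.6%. Compound 3 is therefore expected to give about 85% in this assay, within a range from 65% to 100%.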

Compound 3, percent of the compound remaining: 67.5%
For compound 3 the middle estimate is 17.5 percentage points above the measured one; measured number inside the range.
By their numbers in this assay, from the lowest: compounds 3 and 1 (each within the scatter of the next); then compound 2.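

Exchanging the group with 2 five-membered non-aromatic rings for 3-(dimethylamino)pyrrolidin-1-yl, on an aromatic carbon of the six-membered aromatic ring, gives in this assay a number 32.5 percentage points lower from compound 2 to compound 3 (beyond the scatter) as a large step. For the compounds shown here, this is the only step that can be read across a single place, and it shows that the read-out answers strongly to the group at this aromatic carbon while the rest of the structure stays the same. The two groups have the same counts of hydrogen-bond donors and acceptors and the same net charge, so those counts do not separate them, and nothing measured bears on the reason for the step.

Going by these compounds, whether the step follows the loss of the second ring, the open dimethylamino group or the change from 2 defined stereocentres to 1 stays open, as does the outcome for the opposite stereocentre of the 3-(dimethylamino)pyrrolidin-1-yl group. On these data alone, how a morpholine or a 3-(dimethylamino)azetidin-1-yl group at this aromatic carbon would read in this assay also remains open.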